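The source may hold more compounds than are shown below. What is called first, only, known or untested is meant among the compounds shown, and "the series" means these compounds.

Measured in an ADME assay on MDBK cells (Bos taurus) for cytotoxicity; a lower number here means that less compound is tolerated, a higher number that more compound is tolerated:
Compound 1 `Clc1ccc(Cn2ccc3nc(-c4ccccc4)nc-3c2)cc1Cl`: 71000 nM
Compound 2 `CC(C)CCn1ccc2nc(-c3ccccc3)nc-2c1`: > 100000 nM (a limit of the assay)

Compound 2 gives no number in this assay, only the limit > 100000 nM. Compound 3 `CC(C)=CCn1ccc2nc(-c3ccccc3)nc-2c1` carries 2-methylprop-1-en-1-yl in place of isobutyl on a saturated chain carbon bound to an aromatic nitrogen. Among the measured compounds shown here, the one measured step bearing on this place is an at least 1.4-fold higher number from compound 1 to compound 2 (0.14 log units; that floor lies within the scatter), a different exchange whose floor lies within the scatter. It gives no reason to expect a change in either direction. The expected move is a number no higher from compound 2 to compound 3 (the limit leaves the size open), which means no step beyond the scatter. Compound 3 is estimated at 100000 nM, with an expected range of 50000 nM to 200000 nM.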

Compound 3, half-maximal cytotoxic concentration: > 100000 nM
Compound 3 ended at the assay's limit (the forecaster's own chance of this, stated with the estimate: 60%); the middle value sits exactly at the limit.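

In this assay, compound 3, with its double bond in 2-methylprop-1-en-1-yl, gives only a limit of the assay and no number, just as compound 2 does with isobutyl. Set against 3,4-dichlorophenyl at this place, 2-methylprop-1-en-1-yl gives an at least 1.4-fold higher number from compound 1 to compound 3 (0.14 log units; that floor lies within the scatter), so this floor also does not move beyond the scatter. The exchange of isobutyl for 2-methylprop-1-en-1-yl itself cannot be read, because both compounds stop at the same limit: the limit of > 100000 nM in this assay, at which 2 of the 3 values shown sit.

Going by these compounds, how the two chains truly compare remains open. So does how an amine, a carboxylic acid or a longer chain at this place would read in this assay.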